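The compounds below may be only part of what the source reports. "The series", "measured", "known", "first", "only" and "open" are said of these compounds alone.

In an ADME assay on MDCK cells (Canis lupus familiaris) for permeability, in the apical to basolateral direction (a higher number here means that the compound crosses the layer faster, a lower number that the compound crosses the layer more slowly), compound 2 `Cc1csc(-c2cccc(CNc3ccc4[nH]nc(C(=O)O)c4c3)c2O)n1` gives 4.5 10^-6 cm/s. Compound 1 `CN(C)c1noc(-c2cccc(CN(C)c3ccc4[nH]nc(C(=O)O)c4c3)c2O)n1` gives 3.4 10^-6 cm/s. The values of compound 1 and compound 2 lie within the scatter of each other. Compound 3 `CN(C)c1noc(-c2cccc(CNc3ccc4[nH]nc(C(=O)O)c4c3)c2)n1`, which has no hydroxy group, gives 0.5 10^-6 cm/s. The gap between compound 2 and compound 3 is larger than the usual scatter, with compound 2 the higher of the two. Compound 4 `CC(C)c1noc(-c2cccc(CNc3ccc4[nH]nc(C(=O)O)c4c3)c2O)n1` differs from compound 2 in one place: 3-isopropyl-1,2,4-oxadiazol-5-yl in place of 4-methyl-1,3-thiazol-2-yl on an aromatic carbon. Here 3-isopropyl-1,2,4-oxadiazol-5-yl takes the place of 4-methyl-1,3-thiazol-2-yl on an aromatic carbon, ortho to a hydroxy group. Within the data shown here, no measured pair shows this change alone. Still, compound 4 keeps the hydroxy group, and compound 1, at 3.4 10^-6 cm/s, has both that group and a ring of the entering kind. The expected result is a 1.3-fold lower number from compound 2 to compound 4 (0.11 log units; within the scatter), a slight fall that stays within the scatter. Compound 4 is estimated at 3.5 10^-6 cm/s, with a likely range of 1.5 10^-6 cm/s to 8 10^-6 cm/s.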

Compound 4, apparent permeability: 3.7 10^-6 cm/s
For compound 4 the middle estimate is 1.1-fold (0.02 log units) below the measured one, within the range that was stated.
By their numbers in this assay, from the lowest: compound 3; then compounds 1, 4 and 2 (each within the scatter of the next).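

In this assay the step of a 1.2-fold lower number from compound 2 to compound 4 (0.09 log units; within the scatter) lies within the scatter, so this is direct evidence that 3-isopropyl-1,2,4-oxadiazol-5-yl and 4-methyl-1,3-thiazol-2-yl read alike on this aromatic carbon, ortho to a hydroxy group. No other pair shown isolates this change. The data offer no explanation for this likeness.

As far as these compounds go, it remains open whether a nitrile or a phenyl ring on this carbon would read the same. From the compounds shown here alone, it is also open whether this swap would read the same without the hydroxy group.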